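A few compounds are considered here, and "the series" means these few. Any claim that something is new, unique, unknown or untested is made for them only; others in the source may bear on it.

Measured compounds: compound 1 `CN1CCN(c2ccc(Nc3ncc4nc(Nc5ccc(F)cc5)n([C@@H]5CCN(C(=O)OC(C)(C)C)C5)c4n3)cc2)CC1`, "not determined" (no result reported); compound 2 `CN1CCN(c2ccc(Nc3ncc4nc(Nc5ccccc5)n([C@H]5CCN(S(=O)(=O)C6CC6)C5)c4n3)cc2)CC1`, 540 nM.

Compound 1 has no number in a functional assay on A549 cells (Homo sapiens) for antiproliferative activity, read by MTT assay, with a stated time of 72 h (on this read-out higher numbers stand for weaker inhibition and lower numbers for stronger inhibition), so it cannot be placed on the scale at all. Compound 2 is the only measured point, and in this assay compound 2 gives 540 nM. Compound 3 `CN1CCN(c2ccc(Nc3ncc4nc(Nc5ccc(F)cc5)n([C@H]5CCCN(C(=O)CO)C5)c4n3)cc2)CC1` arises from compound 1 by one change: 1-((hydroxymethyl)carbonyl)piperidin-3-yl in place of 1-(tert-butoxycarbonyl)pyrrolidin-3-yl on an aromatic nitrogen. For the measured compounds named here, with no value for compound 1, neither the size nor the direction of this step can be read from the data; the sole anchor is compound 2, which shares the core. Compound 3 is expected to give about 300 nM in this assay, within a range from 70 nM to 1500 nM.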

Compound 3, half-maximal inhibitory concentration: 830 nM
Compound 3: the middle estimate sits 2.8-fold (0.44 log units) below what was measured; the range from low to high includes it.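

Compound 1 has no number, so no step from it to compound 3 can be read, and nothing shown accounts for the value of compound 3. From the compounds shown here alone, what the exchange of side groups alone does in this assay stays open.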